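Adding a Second Chain to Compound 1

This account rests on a few compounds, and the source may have more. Where it says the series, first, only, none or still open, it means among the compounds named here.

Measured compounds and their values in a functional assay on HeLa cells (Homo sapiens) for inhibition; on this read-out higher numbers stand for weaker inhibition and lower numbers for stronger inhibition:
compound 1, `CC(C)=CC[C@@H]1C[C@]2(CC=C(C)C)C(=O)[C@@](CC=C(C)C)(C(=O)C(C(=O)c3ccc(O)c(O)c3)=C2O)C1(C)C`: 13.7 ug/mL
compound 2, `CC(C)=CCC/C(C)=C/C[C@]12C[C@@H](CC=C(C)C)C(C)(C)[C@](C/C=C(\C)CCC=C(C)C)(C(=O)C(C(=O)c3ccc(O)c(O)c3)=C1O)C2=O`: > 20 ug/mL, which is a limit of the assay rather than a number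
compound 3, `CC(C)=CCC/C(C)=C/C[C@]12C[C@@H](CC=C(C)C)C(C)(C)[C@](CC=C(C)C)(C(=O)C(C(=O)c3ccc(O)c(O)c3)=C1O)C2=O`: 11.7 ug/mL

Compound 1 sits at the highest of the two numbers shown, with compound 3 nearest to it; compound 2 reaches only the assay limit (the limit of > 20 ug/mL in this assay, at which 1 of the 3 values shown sits). The unmeasured compound 4, `CC(C)=CCC/C(C)=C/C[C@@H]1C[C@]2(CC=C(C)C)C(=O)[C@@](CC=C(C)C)(C(=O)C(C(=O)c3ccc(O)c(O)c3)=C2O)C1(C)C`, differs from compound 1 in one place: 3-methylbut-2-en-1-yl in place of hydrogen on a saturated chain carbon bound to a double-bonded chain carbon.

For the measured compounds named here, two measured steps bear on this. The same kind of change gave a 1.2-fold lower number from compound 1 to compound 3 (0.07 log units; within the scatter), a step within the scatter. Adding the group at a further place in the core gave the reverse of an at least 1.7-fold lower number from compound 2 to compound 3 (0.23 log units; that floor lies within the scatter), pushing the value past the limit. Compound 4 is therefore expected to stay near compound 1, with a mild lean toward a higher number, so the expected step is a 1.1-fold higher number from compound 1 to compound 4 (0.04 log units; within the scatter). The estimate for compound 4 is 15 ug/mL, within 7 ug/mL to 30 ug/mL.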

Compound 4, half-maximal inhibitory concentration: > 20 ug/mL
Compound 4 gave a limit, no number (the forecaster's own chance of this, stated with the estimate: 25%); middle value at least 1.3-fold (0.12 log units) away from the limit.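

In this assay compound 4 gives > 20 ug/mL, which is a limit of the assay and not a number. Lengthening 3-methylbut-2-en-1-yl to 3,7-dimethylocta-2,6-dien-1-yl at this place gives an at least 1.4-fold higher number from compound 1 to compound 4 (0.16 log units; that floor lies within the scatter), while the same kind of change at another place gave a 1.2-fold lower number from compound 1 to compound 3 (0.07 log units; within the scatter), so the outcome of this change may depend on which chain is lengthened, though the floor of the first step is too small to settle that. At the place now tested, the longer chain goes with a higher number on both cores: the same change on two cores in this assay, an at least 1.7-fold lower number (0.23 log units; that floor lies within the scatter) from compound 2 to compound 3 and an at least 1.4-fold lower number (0.16 log units; that floor lies within the scatter) from compound 4 to compound 1; the limit leaves it open whether they differ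

As far as these compounds go, how far compound 4 actually lies from compound 1 stays unknown, and the limit also hides any ranking among the compounds that reach it: the limit of > 20 ug/mL in this assay, at which 2 of the 4 values shown sit. Whether an ethyl group, or a chain ending in an amine, would keep a measurable value at this place also remains open.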